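A few compounds are considered here, and "the series" means these few. Any claim that something is new, unique, unknown or untested is made for them only; others in the source may bear on it.

The three measured compounds share one core and differ only in the aryl group carried on an aromatic nitrogen. Compound 1 `COc1cc2c(Oc3ccc(NC(=O)c4cn(-c5ccccc5)nn4)cc3F)ccnc2cc1OCCCN1CCCCC1` gives 210 nM in a functional assay on NCI-H460 cells (Homo sapiens) for cytotoxicity, read by MTT assay, with a stated time of 72 h; a lower number here means a stronger inhibitor, a higher number a weaker inhibitor. Compound 2 `COc1cc2c(Oc3ccc(NC(=O)c4cn(-c5ccc(Br)cc5)nn4)cc3F)ccnc2cc1OCCCN1CCCCC1` gives 360 nM in this assay, and a 1.7-fold higher number from compound 1 to compound 2 (0.23 log units; within the scatter). Compound 3 `COc1cc2c(Oc3ccc(NC(=O)c4cn(-c5c(C)cccc5C)nn4)cc3F)ccnc2cc1OCCCN1CCCCC1` gives 3520 nM in this assay, the highest number of the three: a 17-fold higher number from compound 1 to compound 3 (1.22 log units; beyond the scatter), and a 9.8-fold higher number from compound 2 to compound 3 (0.99 log units; beyond the scatter). Compound 4 `COc1cc2c(Oc3ccc(NC(=O)c4cn(-c5c(Cl)cccc5Cl)nn4)cc3F)ccnc2cc1OCCCN1CCCCC1` is the next step, with 2,6-dichlorophenyl in place of 2,6-dimethylphenyl on an aromatic nitrogen. Among the compounds with values here, no measured pair exchanges a methyl for a chlorine, so the closest guide is the halogen step a 1.7-fold higher number from compound 1 to compound 2 (0.23 log units; within the scatter), which stayed within the scatter, while both steps into compound 3 were large and point to the 2,6-substitution pattern, which compound 4 keeps. The number for compound 4 is therefore expected to stay near that of compound 3. In this assay compound 4 is estimated at 3000 nM, with a range from 1200 nM to 8000 nM. The step this estimate implies, a 1.2-fold lower number from compound 3 to compound 4 (0.07 log units; within the scatter), is expected to lie within the scatter.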

Compound 4, half-maximal inhibitory concentration: 280 nM
Beside the measured number, compound 4's estimate is 11-fold (1.03 log units) above it; the whole stated range lies above it.
By their numbers in this assay, from the lowest: compounds 1, 4 and 2 (each within the scatter of the next); then compound 3.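

In this assay, the step into compound 3 can no longer be read as the cost of any 2,6-disubstituted phenyl on the aromatic nitrogen: exchanging only methyl for chlorine at the same two places gives a 13-fold lower number from compound 3 to compound 4 (1.10 log units; beyond the scatter). The 2,6-dichlorophenyl group stands level with the earlier groups, with a 1.3-fold higher number from compound 1 to compound 4 (0.12 log units; within the scatter) and a 1.3-fold lower number from compound 2 to compound 4 (0.11 log units; within the scatter), so at this position the identity of the two substituents matters, not just their placement. Nothing shown explains why the two groups differ so widely.

On these data alone, it remains open whether the high number belongs to 2,6-dimethylphenyl alone or would recur with methoxy groups, amines or carboxylic acids at those two places. The compounds shown also leave open what a single methyl or a single chlorine on the ring would give.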